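Working notes: swapping the aryl group on the ketone

This account rests on a few compounds, and the source may have more. Where it says the series, first, only, none or still open, it means among the compounds named here.

Compound 1 `Cn1cccc1C(=O)/C=C/c1ccc2c(c1)B(O)OC2` is the open point of the set. In a toxicity assay on MCF-10A cells (Homo sapiens) for cytotoxicity, read by MTT assay, with a stated time of 48 h (a higher number here means a weaker inhibitor, a lower number a stronger inhibitor), compound 1 gives > 100000 nM, which is a limit of the assay and not a number (the limit of > 100000 nM in this assay, at which 1 of the 3 values shown sits). The two other measured members carry a six-membered carbon ring on the carbonyl. In this assay compound 2 `CSc1ccc(C(=O)/C=C/c2ccc3c(c2)B(O)OC3)cc1` gives 7400 nM, and compound 3 `Cc1ccc(C(=O)/C=C/c2ccc3c(c2)B(O)OC3)cc1C` gives 4700 nM. Compound 4 `O=C(/C=C/c1ccc2c(c1)B(O)OC2)c1cccc(O)c1` differs from compound 1 by 3-hydroxyphenyl in place of 1-methyl-1H-pyrrol-2-yl on a carbonyl carbon. Among the compounds with values here, no measured pair covers this change, but compound 4 shares the six-membered carbon ring on the carbonyl with compound 2 and compound 3. The step of an at least 10-fold lower number from compound 1 to compound 4 (1.00 log units; beyond the scatter) is expected to run toward stronger inhibition, beyond the scatter. Compound 4 is estimated at 10000 nM, with a range of 3000 nM to 50000 nM.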

Compound 4, half-maximal inhibitory concentration: 25300 nM
The estimate for compound 4 lay 2.5-fold (0.40 log units) below the measured number; the range from low to high includes it.
By their numbers in this assay, from the lowest: compounds 3 and 2 (each within the scatter of the next); then compound 4. At a limit, above all of these: compound 1.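

In this assay, within the data shown here, the step on this carbonyl carbon is the first that can be read at this position: an at least 3.9-fold lower number from compound 1 to compound 4 (0.59 log units; beyond the scatter). Compound 1 stands at a limit and not a number, so the step gives only a lower bound on the size of the change: the limit of > 100000 nM in this assay, at which 1 of the 4 values shown sits. With 3-hydroxyphenyl in place, compound 4 gives 25300 nM, while compound 2 gives 7400 nM and compound 3 gives 4700 nM.

Still open, as far as these compounds go, is what a plain phenyl, or a phenyl carrying an amine or a carboxylic acid, would give on the carbonyl carbon. That leaves undecided whether the hydroxy group or the six-membered ring carries the step.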